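One Fluorine, Three Positions: From Compound 3 to Compound 4

The source may hold more compounds than are shown below. What is called first, only, known or untested is meant among the compounds shown, and "the series" means these compounds.

Measured so far:
- compound 1, `OC(c1ncccc1F)C1(c2ccc(Cl)c(Cl)c2)CCC1`: 610 nM
- compound 2, `O[C@]1(c2ccccn2)CC[C@@H](c2ccc(C(F)(F)F)cc2)C1`: 130 nM
- compound 3, `OC(c1cc(F)ccn1)C1(c2ccc(Cl)c(Cl)c2)CCC1`: 640 nM

All three were tested in an assay on HEK293 cells for antagonist activity at transient receptor potential cation channel subfamily V member 3 (Homo sapiens), read by FLIPR and calcium flux; a higher number here means a weaker inhibitor, a lower number a stronger inhibitor. Compound 3 gives 640 nM, the highest of the three numbers. Compound 1 sits closest, and the step of a 1.0-fold higher number from compound 1 to compound 3 (0.02 log units; within the scatter) lies within the scatter, so the two cannot be told apart. Among the compounds with values here, compound 2 gives 130 nM, the lowest number, and no single-change step connects it to compound 3.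

Compound 4, `OC(c1ccc(F)cn1)C1(c2ccc(Cl)c(Cl)c2)CCC1`, has the same atoms as compound 3 joined differently: 5-fluoropyridin-2-yl in place of 4-fluoropyridin-2-yl on a saturated chain carbon bound to an oxygen on a saturated carbon and a saturated ring carbon. Within the data shown here, only one measured step speaks to this kind of change. Moving the fluorine from the 3-position to the 4-position of the pyridin-2-yl group, from compound 1 to compound 3, left this assay unchanged within the scatter. Moving it once more, to the 5-position, is a change of the same kind, so no step beyond the scatter is expected in either direction, and the expected step of a 1.1-fold lower number from compound 3 to compound 4 (0.03 log units; within the scatter) is small. Compound 4 is therefore estimated at 600 nM, with a plausible range from 250 nM to 1500 nM.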

Compound 4, antagonist equilibrium constant: 910 nM
Compound 4: middle estimate off by 1.5-fold (0.18 log units), on the low side; low and high end bracket the measured number.
By their numbers in this assay, from the lowest: compound 2; then compounds 1, 3 and 4 (each within the scatter of the next).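

With compound 4 measured, the fluorine has now been tried at three places on the pyridin-2-yl group, so the comparison no longer rests on a single pair. In this assay, the step of a 1.4-fold higher number from compound 3 to compound 4 (0.15 log units; within the scatter) and the step of a 1.5-fold higher number from compound 1 to compound 4 (0.17 log units; within the scatter) are both within the scatter, as is the earlier step between the 3-fluoropyridin-2-yl and 4-fluoropyridin-2-yl compounds, so compounds 1, 3 and 4 cannot be told apart. On this shared core, then, the three fluorine placements give no measurable separation, which suggests that moving this one atom around the ring is not a useful way to change the number, although this holds only for these three compounds. Nothing available here explains why the three placements read alike.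

Going by these compounds, what remains open is whether a different group on the pyridin-2-yl ring, such as a nitrile or an amine in place of the fluorine, would give a step beyond the scatter. Compound 2 differs from the other three in more than one place, so its lower number cannot be tied to any single part of its structure.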